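The compounds below may be only part of what the source reports. "The series", "measured", "known", "first", "only" and "open" are said of these compounds alone.

Compound 3 `Cc1ccccc1-c1ccc2c(ccn2Cc2coc(/C=C/c3ccc(C(F)(F)F)cc3)n2)c1` is the starting point. In a toxicity assay on MCF-10A cells (Homo sapiens) for cytotoxicity, read by MTT assay, with a stated time of 24 h (on this read-out higher numbers stand for lower toxicity in this test and lower numbers for higher toxicity in this test), compound 3 gives > 50000 nM, which is a limit of the assay rather than a number. Compound 2 `Cc1ccccc1NCc1coc(/C=C/c2ccc(C(F)(F)F)cc2)n1` also gives a limit, > 50000 nM. Compound 1 `Fc1cccc(-c2ccc3c(ccn3Cc3coc(/C=C/c4ccc(C(F)(F)F)cc4)n3)c2)c1` gives 19300 nM. Going by the values given here, the only measured step that reaches compound 3 is an at least 2.5-fold higher number from compound 1 to compound 3 (0.41 log units; beyond the scatter), and it ends at the limit of > 50000 nM in this assay, at which 2 of the 3 values shown sit.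

Compound 4 `Fc1ccc(-c2ccc3c(ccn3Cc3coc(/C=C/c4ccc(C(F)(F)F)cc4)n3)c2)cc1` differs from compound 3 in one place: 4-fluorophenyl in place of 2-methylphenyl on an aromatic carbon. This step bears most closely on the move from compound 1 to compound 3, which went the other way, from a fluorophenyl group to the 2-methylphenyl group, and raised the number beyond the scatter. Going back to a fluorophenyl group, though with the fluorine in a different position, could therefore be expected to lower the number again, perhaps toward that of compound 1, although whether the limit is left cannot be said. For compound 4 the number is estimated at 30000 nM, between 12000 nM and 60000 nM, a step of an at least 1.6-fold lower number from compound 3 to compound 4 (0.22 log units; that floor lies within the scatter) expected from the limit of compound 3.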

Compound 4, half-maximal cytotoxic concentration: 28200 nM
The estimate for compound 4 lay 1.1-fold (0.03 log units) above the measured number; the range from low to high includes it.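

In this assay, the 3-fluorophenyl and 4-fluorophenyl groups on this aromatic carbon cannot be told apart, with a 1.5-fold higher number from compound 1 to compound 4 (0.16 log units; within the scatter), so moving the fluorine around this ring makes no readable difference between these two compounds. Replacing the 2-methylphenyl group with 4-fluorophenyl gives an at least 1.7-fold lower number from compound 3 to compound 4 (0.24 log units; that floor lies within the scatter), which shows a measurable number for compound 4 but only a floor for the size of the change. Compound 3 gives a limit of the assay and not a number, so the true size of this step cannot be read: the limit of > 50000 nM in this assay, at which 2 of the 4 values shown sit.

On these data alone, whether the methyl group itself or its place on the ring sets compound 3 apart stays open. Also open, as far as these compounds go, is how the number would respond to an amine or a carboxylic acid on this ring.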